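Fluoro to oxime-bearing group on the fused ring

A few compounds are considered here, and "the series" means these few. Any claim that something is new, unique, unknown or untested is made for them only; others in the source may bear on it.

Going by the values given here, in an assay on isolated protein for inhibition of long-chain fatty acid transport protein 1 (Mus musculus) (a lower number here means a stronger inhibitor, a higher number a weaker inhibitor), compound 2 `CCn1c(CNc2ccccc2)nnc1SCc1nc2cc(F)ccc2o1` stands at 7800 nM, the only number so far. Compound 1 `CCn1c(CNc2ccccc2)nnc1SCC(=O)Nc1ccccc1` sits at the limit of > 10000 nM in this assay, at which 1 of the 2 values shown sits, a limit of the assay and not a number, its reading being > 10000 nM. Compound 3 `CC/C(=N/O)c1ccc2oc(CSc3nnc(CNc4ccccc4)n3CC)nc2c1` differs from compound 2 by a group of 5 heavy atoms (3 carbon, 1 nitrogen, 1 oxygen; no ring) in place of one fluorine atom, on an aromatic carbon. Among the compounds with values here, no measured step covers this change; a small gain in inhibition, hardly beyond the scatter, is expected. Compound 3 is estimated at 4500 nM, between 1500 nM and 12000 nM. The expected step is a 1.7-fold lower number from compound 2 to compound 3 (0.24 log units; within the scatter).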

Compound 3, half-maximal inhibitory concentration: 200 nM
Compound 3: middle estimate off by 23-fold (1.35 log units), on the high side; the whole stated range lies above it.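

In this assay, swapping fluoro for the oxime-bearing group on this aromatic carbon gives a 39-fold lower number from compound 2 to compound 3 (1.59 log units; beyond the scatter), a large step and the first readable one in the series. The earlier compounds shown here offered one number and one limit, so they showed nothing about how sensitive this place on the fused ring system is to substitution. Nothing measured here bears on the cause of the step. On these data alone, whether the gain requires the oxime itself remains open. A ketone or a plain propyl chain on the same carbon would test this.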